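Trifluoromethyl in Place of Methoxy at the Assay Limit

The source may hold more compounds than are shown below. What is called first, only, known or untested is meant among the compounds shown, and "the series" means these compounds.

Of the compounds shown here, three have been tested in a functional assay on PC-3 cells (Homo sapiens) for inhibition, read by MTT assay, with a stated time of 24 h; on this read-out higher numbers stand for weaker inhibition and lower numbers for stronger inhibition. Compound 1 `CCCCCCCCCCn1cc(/C=[N+](\[O-])c2ccccc2)nn1` reaches only the limit of the assay, with > 100000 nM. Compound 2 `[O-]/[N+](=C\c1cn(-c2ccc(F)cc2)nn1)Cc1ccccc1` likewise gives only a limit, > 100000 nM. Compound 3 `COc1ccc(-n2cc(/C=[N+](\[O-])Cc3ccccc3)nn2)cc1` also gives only a limit, > 100000 nM. Among the measured compounds shown here, all three values sit at the limit (the limit of > 100000 nM in this assay, at which 3 of the 3 values shown sit), so no compound can be placed above or below another, and the one change between measured compounds, a step that the two limits leave unreadable from compound 2 to compound 3, cannot be read in size or direction.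

Compound 4 `[O-]/[N+](=C\c1cn(-c2ccc(C(F)(F)F)cc2)nn1)Cc1ccccc1` is the next compound to be measured. It differs from compound 3 by trifluoromethyl in place of methoxy on an aromatic carbon. For the measured compounds named here, no measured step tells how this change acts in this assay, and the one neighbouring step, between compound 2 and compound 3, is itself unreadable. Compound 4 is expected to remain at or near the assay limit, with an estimate of 150000 nM spanning from 30000 nM to 600000 nM. The step from compound 3 to compound 4 that this estimate means is expected to be a step that the limit leaves unreadable from compound 3 to compound 4.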

Compound 4, half-maximal inhibitory concentration: > 100000 nM
Compound 4: no number, only a limit; the forecaster's own chance of this, stated with the estimate: 85%; the middle value lies beyond the limit too.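

Compound 4 also gives only a limit, so the steps linking compound 2, compound 3 and compound 4 cannot be read in size or direction: the limit of > 100000 nM in this assay, at which 4 of the 4 values shown sit.

The compounds shown leave open whether any change among these structures would give a true number in this assay, and which change that would be.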